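Chain extension on the anilino arm of the shared core

A few compounds are considered here, and "the series" means these few. Any claim that something is new, unique, unknown or untested is made for them only; others in the source may bear on it.

Notes on the series. Compound 1 `Oc1nc2nonc2nc1Nc1ccccc1` is the parent; in an assay on mitochondria from L6 cells (Rattus norvegicus) for activation, with a stated time of 90 min (on this read-out higher numbers stand for an effect only at larger amounts of compound and lower numbers for an effect already at smaller amounts), compound 1 gives 66700 nM. Compound 2 `CC(C)(C)c1ccc(Nc2nc3nonc3nc2O)cc1` gives 3900 nM, and compound 3 `CCCCc1ccc(Nc2nc3nonc3nc2O)cc1` gives 2100 nM. Compound 3 holds the lowest of the three numbers; its nearest neighbour is compound 2, and that distance (a 1.9-fold lower number from compound 2 to compound 3 (0.27 log units; within the scatter)) stays within the scatter, so no order between the two can be read. Both steps from compound 1 were large: a 17-fold lower number from compound 1 to compound 2 (1.23 log units; beyond the scatter) and a 32-fold lower number from compound 1 to compound 3 (1.50 log units; beyond the scatter).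

Compound 4 `CCCCCCc1ccc(Nc2nc3nonc3nc2O)cc1` differs from compound 3 by ethyl in place of hydrogen on a saturated chain carbon, four bonds along the chain from an aromatic carbon. Going by the values given here, no measured step tests this kind of change directly. The large gain from compound 1 to compound 3 came from placing butyl where hydrogen stood, whereas exchanging tert-butyl for butyl stayed within the scatter, so lengthening the chain further is expected to move the number only a little, if at all downward. For compound 4 the expected step is a 1.4-fold lower number from compound 3 to compound 4 (0.15 log units; within the scatter). Compound 4 is therefore estimated at 1500 nM, with a range from 500 nM to 5000 nM.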

Compound 4, half-maximal effective concentration: 4700 nM
Beside the measured number, compound 4's estimate is 3.1-fold (0.50 log units) below it, and the stated range covers the measured number.
By their numbers in this assay, from the lowest: compounds 3, 2 and 4 (each within the scatter of the next, the first and the last beyond it); then compound 1.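

In this assay, extending butyl to hexyl does not carry the earlier gain further: the change gives a 2.2-fold higher number from compound 3 to compound 4 (0.35 log units; beyond the scatter) and so runs against the large drop seen when butyl replaced hydrogen on the aromatic carbon. The hexyl chain still retains a clear advantage over the unsubstituted parent, with a 14-fold lower number from compound 1 to compound 4 (1.15 log units; beyond the scatter) on record, so the added length gives back only a small part of that drop. Hexyl and tert-butyl cannot be separated at this place, as a 1.2-fold higher number from compound 2 to compound 4 (0.08 log units; within the scatter) shows, so two quite different groups give matching numbers here, while the two straight chains do differ.

Nothing at hand explains the reversal on chain extension. From the compounds shown here alone, whether pentyl sits with butyl or with hexyl remains open, as does the effect of an octyl chain or of an amine at the chain end.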